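From benzyl to (3-methoxyphenyl)carbonyl on the shared core

This account rests on a few compounds, and the source may have more. Where it says the series, first, only, none or still open, it means among the compounds named here.

Antiproliferative values in a functional assay on B16 cells (Mus musculus) for antiproliferative activity, read by MTT assay, with a stated time of 24 h; on this read-out higher numbers stand for weaker inhibition and lower numbers for stronger inhibition:
compound 1 `COc1cc(OC)c(-c2coc3cc(OCC=C(C)C)ccc3c2=O)cc1OC` gives 1090 nM
compound 2 `C=CCOc1ccc2c(=O)c(-c3cc(OC)c(OC)cc3OC)coc2c1` gives 5100 nM
compound 3 `COc1cc(OC)c(-c2coc3cc(OCc4ccccc4)ccc3c2=O)cc1OC` gives 2330 nM

Compound 3 holds the second highest of the three numbers, so it sits in the middle. Compound 4 `COc1cccc(C(=O)Oc2ccc3c(=O)c(-c4cc(OC)c(OC)cc4OC)coc3c2)c1` has not yet been measured. It carries (3-methoxyphenyl)carbonyl in place of benzyl on an oxygen on an aromatic ring.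

The nearest guides are the two steps that also replace a group at this part of the molecule and involve compound 3: a 2.1-fold higher number from compound 1 to compound 3 (0.33 log units; beyond the scatter) and a 2.2-fold lower number from compound 2 to compound 3 (0.34 log units; beyond the scatter). Both are modest, as is a 4.7-fold higher number from compound 1 to compound 2 (0.67 log units; beyond the scatter). None of the three steps introduces a carbonyl, however, so the direction of the new step cannot be read from these data.

Expected in this assay is a 1.2-fold lower number from compound 3 to compound 4 (0.07 log units; within the scatter), with a move of modest size at most. For compound 4 the estimate is 2000 nM and the expected range runs from 600 nM to 7000 nM on this estimate.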

Compound 4, half-maximal inhibitory concentration: > 10000 nM
Compound 4: only a limit was reported; the forecaster's own chance of this, stated with the estimate: 3%; middle value at least 5.0-fold (0.69 log units) from the limit.
By their numbers in this assay, from the lowest: compound 1; then compound 3; then compound 2. At a limit, above all of these: compound 4.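

What is reported for compound 4 is a limit of the assay, not a number, so every step to it is a floor: the limit of > 10000 nM in this assay, at which 1 of the 4 values shown sits. Among 3-methylbut-2-en-1-yl, allyl and benzyl on this oxygen, the numbers in this assay all stayed measurable, whereas (3-methoxyphenyl)carbonyl, which keeps a six-membered aromatic ring as benzyl does, brings an at least 4.2-fold higher number from compound 3 to compound 4 (0.63 log units; beyond the scatter) and an at least 9.1-fold higher number from compound 1 to compound 4 (0.96 log units; beyond the scatter). Against the allyl group the step is an at least 1.9-fold higher number from compound 2 to compound 4 (0.29 log units; that floor lies within the scatter), so this comparison alone does not separate the two compounds.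

The change adds both a carbonyl and a methoxy group, and the compounds shown cannot tell which of the two matters. A plain phenylcarbonyl group and a 3-methoxybenzyl group on the same oxygen would pull these two parts apart.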